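This account rests on a few compounds, and the source may have more. Where it says the series, first, only, none or still open, it means among the compounds named here.

Within the data shown here, compound 1 `CC(C)(C)c1ccc(-c2cc(Nc3ccc4c(c3)OCCO4)ncn2)cc1` has the lowest of the two numbers measured so far. In a functional assay on CHO cells for antagonist activity at transient receptor potential cation channel subfamily V member 1 (Rattus norvegicus), read by calcium flux (a higher number here means a weaker inhibitor, a lower number a stronger inhibitor), compound 1 gives 120 nM. Compound 2 `CC(C)(C)c1ccc(-c2cnnc(Nc3ccc4c(c3)OCCO4)c2)cc1` belongs to the same series; in this assay compound 2 gives 780 nM, a clearly higher number that lies beyond the scatter. Compound 3 `FC(F)(F)c1ccc(-c2cc(Nc3ccc4c(c3)OCCO4)ncn2)cc1` differs from compound 1 in one place: trifluoromethyl in place of tert-butyl on an aromatic carbon. Among the measured compounds shown here, no measured pair shows this exchange, so its effect here is unknown. The step of a 2.1-fold higher number from compound 1 to compound 3 (0.32 log units; beyond the scatter) that the estimate means is expected to be a modest rise in the number, close to the usual scatter. Compound 3 is expected to give about 250 nM in this assay, within 80 nM to 800 nM.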

Compound 3, half-maximal inhibitory concentration: 430 nM
Estimate against measurement, compound 3: 1.7-fold (0.24 log units) below, within the range that was stated.
By their numbers in this assay, from the lowest: compound 1; then compounds 3 and 2 (each within the scatter of the next).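

In this assay, the position on the aromatic carbon para to a large group responds to a change of group: trifluoromethyl in place of tert-butyl gives a 3.6-fold higher number from compound 1 to compound 3 (0.55 log units; beyond the scatter). Among these compounds, this is the first measured exchange at this position, and of the two groups, tert-butyl gives the stronger inhibitor. Nothing available explains the rise. Still open, as far as these compounds go, is how an isopropyl group, a methyl group or a chlorine atom would fare at this position, and whether the same exchange would give a similar step on the core of compound 2.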